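Swapping a halogen for dimethylamino on a weak aorta inhibitor

A few compounds are considered here, and "the series" means these few. Any claim that something is new, unique, unknown or untested is made for them only; others in the source may bear on it.

Compound 1 `CCOc1nc(-c2cc3ccccc3o2)cc(-c2ccc(Br)cc2)c1C#N` and compound 2 `CCOc1nc(-c2cc3ccccc3o2)cc(-c2ccc(F)cc2)c1C#N` share one core and differ in a single substituent. In a functional assay on aorta (strain Wistar) for inhibition, with Thoracic aorta (Rattus norvegicus) as the target (on this read-out lower numbers stand for stronger inhibition and higher numbers for weaker inhibition), compound 1 gives 227000 nM, and compound 2 gives 396000 nM. Among the compounds with values here, the step of a 1.7-fold higher number from compound 1 to compound 2 (0.24 log units; within the scatter) is the only comparison available. Compound 2 therefore shows the higher of the two numbers, but since its gap to compound 1 lies within the scatter, the two cannot be ranked.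

Compound 3 `CCOc1nc(-c2cc3ccccc3o2)cc(-c2ccc(N(C)C)cc2)c1C#N` carries the change (dimethylamino in place of fluoro on an aromatic carbon). Within the data shown here, the only measured step touching this position is the halogen swap from compound 1 to compound 2, and it stayed within the scatter; no measured step introduces a dimethylamino group anywhere. Without evidence of a sizable effect at this position, the step of a 1.4-fold lower number from compound 2 to compound 3 (0.15 log units; within the scatter) is expected to stay within the scatter. Compound 3 in this assay is estimated at 280000 nM, with a range from 80000 nM to 1000000 nM.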

Compound 3, half-maximal inhibitory concentration: 338000 nM
For compound 3 the middle estimate is 1.2-fold (0.08 log units) below the measured one, and the stated range covers the measured number.
By their numbers in this assay, from the lowest: compounds 1, 3 and 2 (each within the scatter of the next).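

In this assay, dimethylamino, with 3 heavy atoms and 1 hydrogen-bond acceptor, takes the place of a single halogen atom, yet both comparisons stay within the scatter: a 1.2-fold lower number from compound 2 to compound 3 (0.07 log units; within the scatter), and a 1.5-fold higher number from compound 1 to compound 3 (0.17 log units; within the scatter). The earlier pair showed this only for one halogen swapped for another, whereas bromo, fluoro and dimethylamino now cannot be told apart on this aromatic carbon, para to a large group. No supporting data are available to explain this result.

As far as these compounds go, it remains open whether a carboxylic acid, a primary amine or a longer chain at this position would move the number beyond the scatter. The compounds shown also leave open whether any change elsewhere on the shared core, such as replacing the nitrile with a carboxylic acid, would do so.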